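Ring size and ring opening at the benzotriazole substituent

The compounds below may be only part of what the source reports. "The series", "measured", "known", "first", "only" and "open" are said of these compounds alone.

Compound 1 `Brc1cccc2c1nnn2CC1CCCC1`: 30 nM
Compound 2 `Brc1cccc2c1nnn2CC1CCC1`: 20 nM
Compound 3 `Brc1cccc2c1nnn2CC1CC1`: 70 nM

The three measured compounds share one core and differ only in the ring attached to the saturated chain carbon bound to an aromatic nitrogen. In a functional assay on cells for positive allosteric modulation of metabotropic glutamate receptor 2 (Homo sapiens), read by fluorescence and calcium flux, with a stated time of 30 min (on this read-out lower numbers stand for an effect already at smaller amounts and higher numbers for an effect only at larger amounts of compound), compound 3 gives 70 nM, the highest number of the three. The step of a 2.3-fold higher number from compound 1 to compound 3 (0.37 log units; beyond the scatter) and the step of a 3.5-fold higher number from compound 2 to compound 3 (0.54 log units; beyond the scatter) both point the same way, while the step of a 1.5-fold lower number from compound 1 to compound 2 (0.18 log units; within the scatter) stays within the scatter.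

Compound 4 `CC(C)Cn1nnc2c(Br)cccc21` has not been measured. Its change from compound 3 is isopropyl in place of cyclopropyl on a saturated chain carbon bound to an aromatic nitrogen. For the measured compounds named here, no measured step compares a ring with an open chain, so the steps above bear on it only indirectly: they show that among the small rings the smallest gives the highest number, but nothing shows whether an open chain of the same count behaves like a larger or a smaller ring. The expected step of a 1.4-fold lower number from compound 3 to compound 4 (0.15 log units; within the scatter) is therefore not beyond the scatter. Compound 4 is estimated at 50 nM, with a range from 15 nM to 160 nM.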

Compound 4, half-maximal effective concentration: 140 nM
Compound 4: the middle estimate sits 2.8-fold (0.45 log units) below what was measured; low and high end bracket the measured number.
By their numbers in this assay, from the lowest: compounds 2 and 1 (each within the scatter of the next); then compounds 3 and 4 (each within the scatter of the next).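

For the compounds shown here, replacing cyclopropyl with isopropyl on a saturated chain carbon bound to an aromatic nitrogen gives the first comparison of a ring with an open chain at this position, and in this assay the step of a 2.0-fold higher number from compound 3 to compound 4 (0.30 log units; within the scatter) stays within the scatter. Against the larger rings the open chain stands apart, with a 7.0-fold higher number from compound 2 to compound 4 (0.85 log units; beyond the scatter) and a 4.7-fold higher number from compound 1 to compound 4 (0.67 log units; beyond the scatter) both beyond the scatter, so the presence of a ring does not by itself separate these compounds: compound 3 groups with compound 4 and not with compound 1 or compound 2. Nothing among the data shown accounts for this grouping.

From the compounds shown here alone, whether a longer chain such as n-butyl would group with the larger rings or with compound 4 remains open. So does the place of an amine or a carboxylic acid on this chain carbon.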